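The compounds below may be only part of what the source reports. "The series", "measured", "known", "first", "only" and "open" are said of these compounds alone.

In a functional assay on NT2 cells (Homo sapiens) for inhibition (on this read-out lower numbers stand for stronger inhibition and higher numbers for weaker inhibition), the measured compounds are:

- Compound 1 `CCCCCCN(C)CNCC(=O)[C@H](CC(=O)O)NC(=O)C(CC)n1cc(C(C)(CC)CC)nc(NCc2nonc2C)c1=O`: 0.025 nM
- Compound 2 `CCCCCCN(C)CNCC(=O)[C@H](CC(=O)O)NC(=O)C(CC)n1ccnc(NCc2nonc2C)c1=O`: 0.13 nM
- Compound 3 `CCCCCCN(C)CNCC(=O)[C@H](CC(=O)O)NC(=O)C(CC)n1cc(CC)nc(NCc2nonc2C)c1=O`: 0.078 nM

Two steps show where compound 2 stands: a 1.7-fold lower number from compound 2 to compound 3 (0.22 log units; within the scatter), and a 5.2-fold higher number from compound 1 to compound 2 (0.72 log units; beyond the scatter). Compound 2 therefore shares its level with compound 3, and only compound 1 lies clearly apart from it.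

Compound 4 `CCC(C(=O)N[C@@H](CC(=O)O)C(=O)CNCN1CCc2ccccc2C1)n1ccnc(NCc2nonc2C)c1=O` keeps the rest of compound 2 and changes one group: 1,2,3,4-tetrahydroisoquinolin-2-yl in place of hexyl(methyl)amino on a saturated chain carbon bound to an amine nitrogen.

Among the measured compounds shown here, no measured step touches this place. All three change the group on an aromatic carbon, and the largest is the modest one already given, alongside a 3.1-fold higher number from compound 1 to compound 3 (0.49 log units; beyond the scatter). These steps show how far numbers have moved in this series, but they say nothing about the direction of a change at the new place. With no direction to argue for, no shift beyond the scatter is expected in this assay, although the uncertainty is wide. The expected change is a 1.2-fold higher number from compound 2 to compound 4 (0.06 log units; within the scatter). For compound 4 the estimated value is 0.15 nM, with an expected range from 0.04 nM to 0.6 nM.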

Compound 4, half-maximal inhibitory concentration: 1.25 nM
For compound 4 the middle estimate is 8.3-fold (0.92 log units) below the measured one, and the stated range ends below it.
By their numbers in this assay, from the lowest: compound 1; then compounds 3 and 2 (each within the scatter of the next); then compound 4.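

In this assay, the group on the saturated chain carbon bound to an amine nitrogen proves able to shift the result: replacing the open-chain hexyl(methyl)amino with the ring-containing 1,2,3,4-tetrahydroisoquinolin-2-yl gives a 9.6-fold higher number from compound 2 to compound 4 (0.98 log units; beyond the scatter), which means weaker inhibition. Among the compounds shown here, the earlier compounds varied only the group on an aromatic carbon, with steps such as a 5.2-fold higher number from compound 1 to compound 2 (0.72 log units; beyond the scatter), so this is the first sign that the amine end of the molecule also matters, and on a scale no smaller than those earlier changes. Nothing measured here explains why this swap weakens inhibition.

This single swap removes the hexyl chain and brings in two rings at once, so it cannot show which of these changes accounts for the shift; a butyl(methyl)amino group or a piperidin-1-yl group at the same place would help to separate them. From the compounds shown here alone, it also remains open whether the same swap would have a similar effect on compound 1 , which carries 1-ethyl-1-methylpropyl on the aromatic carbon.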